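A few compounds are considered here, and "the series" means these few. Any claim that something is new, unique, unknown or untested is made for them only; others in the source may bear on it.

Compound 1 `CC(C)=CC(=O)Nc1cc2c(N3CCc4ccccc43)ncnc2cc1O[C@@H]1CCOC1` in a functional assay on A549 cells (Homo sapiens) for antiproliferative activity, read by MTT assay, with a stated time of 72 h (on this read-out lower numbers stand for stronger inhibition and higher numbers for weaker inhibition), gives 3670 nM. Compound 2 `C/C=C/C(=O)Nc1cc2c(N3CCc4ccccc43)ncnc2cc1O[C@@H]1CCOC1` in this assay gives 2610 nM. Compound 3 `COc1cc2ncnc(N3CCCc4ccccc43)c2cc1NC(=O)C=C(C)C` in this assay gives 5410 nM.

Compound 2 differs from compound 1 by one change, (prop-1-en-1-yl in place of 2-methylprop-1-en-1-yl on a carbonyl carbon), and that step was a 1.4-fold lower number from compound 1 to compound 2 (0.15 log units; within the scatter). Compound 4 `C/C=C/C(=O)Nc1cc2c(N3CCCc4ccccc43)ncnc2cc1OC` has not yet been measured; it differs from compound 3 by prop-1-en-1-yl in place of 2-methylprop-1-en-1-yl on a carbonyl carbon, the same change at the same kind of place. How the core of compound 1 and the core of compound 3 differ is not broken down here; their two values simply show compound 3 with the higher number. In this assay, among the measured compounds shown here, the expected step is a 1.4-fold lower number from compound 3 to compound 4 (0.14 log units; within the scatter), because a 1.4-fold lower number from compound 1 to compound 2 (0.15 log units; within the scatter) stayed within the scatter, and only that single example of the change is available. Compound 4 is therefore estimated at 3900 nM, within a range of 2000 nM to 7500 nM.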

Compound 4, half-maximal inhibitory concentration: 8190 nM
Estimate against measurement, compound 4: 2.1-fold (0.32 log units) below; the whole stated range lies below it.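

In this assay, putting prop-1-en-1-yl in place of 2-methylprop-1-en-1-yl on a carbonyl carbon gave a 1.5-fold higher number from compound 3 to compound 4 (0.18 log units; within the scatter). Set beside the same change on the other core, this step does not differ from it: the same change on two cores in this assay, a 1.4-fold lower number (0.15 log units; within the scatter) from compound 1 to compound 2 and a 1.5-fold higher number (0.18 log units; within the scatter) from compound 3 to compound 4, 2.1-fold (0.33 log units) apart, within the scatter of two such steps. Among the compounds shown here, the two pairs therefore show no sign that the outcome of this change depends on the core, but they do not show that it carries over with a reliable size or direction, since only two pairs are available and each step lies within the scatter.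

The compounds shown leave open whether a larger change at this carbonyl carbon, such as a chain ending in a dimethylamino group, would give a step beyond the scatter. They also leave open how such a group would behave on each of the two cores.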